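Taking the bromo group off compound 2

A few compounds are considered here, and "the series" means these few. Any claim that something is new, unique, unknown or untested is made for them only; others in the source may bear on it.

Of the compounds shown here, two sharing one core have been measured so far in a functional assay on HepG2 cells (Homo sapiens) for cytotoxicity, read by MTT assay, with a stated time of 72 h; a higher number here means a weaker inhibitor, a lower number a stronger inhibitor. Compound 1 `O=C(N/N=C/c1cccc(Cl)c1Cl)Nc1cc2c(Nc3ccc(F)c(Cl)c3)ncnc2cc1O[C@H]1CCOC1` gives 16900 nM. Compound 2 `O=C(N/N=C/c1ccc(O)c(Br)c1)Nc1cc2c(Nc3ccc(F)c(Cl)c3)ncnc2cc1O[C@H]1CCOC1` gives 660 nM, the lower of the two numbers. Compound 3 `O=C(N/N=C/c1ccc(O)cc1)Nc1cc2c(Nc3ccc(F)c(Cl)c3)ncnc2cc1O[C@H]1CCOC1` is next, and it differs from compound 2 in one place: hydrogen in place of bromo on an aromatic carbon. In words, hydrogen stands in place of bromo on an aromatic carbon, ortho to a hydroxy group, so 3-bromo-4-hydroxyphenyl becomes 4-hydroxyphenyl.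

Among the compounds with values here, only one measured step bears on this change: a 26-fold lower number from compound 1 to compound 2 (1.41 log units; beyond the scatter). Within the data shown here, that step is large, but it altered more than a single bromo group, so no measured pair shows the effect of bromo alone. Compound 3 keeps the hydroxy group of compound 2, so its number is expected to stay closer to compound 2 at 660 nM than to the other measured value. The direction of the change is uncertain. The change is estimated to be modest and to lean towards a higher number, at a 2.3-fold higher number from compound 2 to compound 3 (0.36 log units; beyond the scatter). For compound 3 the estimated value is 1500 nM, with an expected range from 400 nM to 6000 nM.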

Compound 3, half-maximal inhibitory concentration: 70 nM
Compound 3: middle estimate off by 21-fold (1.33 log units), on the high side; measured number outside the range, below it.
By their numbers in this assay, from the lowest: compound 3; then compound 2; then compound 1.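

In this assay, within the data shown here, the bromo group ortho to a hydroxy group proves to be a cost rather than a help: taking it off gives a 9.4-fold lower number from compound 2 to compound 3 (0.97 log units; beyond the scatter) and is the first change here that concerns this one atom alone. Replacing 2,3-dichlorophenyl with the simpler 4-hydroxyphenyl gives a 240-fold lower number from compound 1 to compound 3 (2.38 log units; beyond the scatter) and makes compound 3 the strongest of the three, so the earlier drop from compound 1 to compound 2 cannot be credited to the bromo group. The data give the size of these changes, but no measurement is available to explain them.

As far as these compounds go, whether this result is specific to bromo or would hold for any group larger than hydrogen at this position remains open, and a chloro, methyl or methoxy group there could land on either side of compound 3. The contribution of the hydroxy group is also unresolved, and an amine in its place on the 4-hydroxyphenyl ring would be one way to probe it.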